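Swapping a halogenated ring on a shared core

The compounds below may be only part of what the source reports. "The series", "measured", "known", "first", "only" and "open" are said of these compounds alone.

Compound 1 `C=CCn1c(=O)/c(=C\c2cccc(Br)c2)[nH]c(=O)/c1=C\c1ccccc1OC` is the anchor of this small set. For the measured compounds named here, in a functional assay on A549 cells (Homo sapiens) for cytotoxicity, read by CCK-8 assay, with a stated time of 72 h (a higher number here means a weaker inhibitor, a lower number a stronger inhibitor), compound 1 gives 5400 nM, and that is the only number in hand: a second member, compound 2 `C=CCn1c(=O)/c(=C\c2cccc(Br)c2)[nH]c(=O)/c1=C\c1cccc(Br)c1`, is reported in this assay only as "not active" (no number reported), with no figure attached. Compound 1 therefore stands alone on the numbers shown, with nothing to rank it against.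

Compound 3 `C=CCn1c(=O)/c(=C\c2ccc(Cl)c(Cl)c2)[nH]c(=O)/c1=C\c1ccccc1OC` has not yet been measured. Compared with compound 1 it differs in one place, (3,4-dichlorophenyl in place of 3-bromophenyl on a double-bonded chain carbon bound to an aromatic carbon). Going by the values given here, no step between two measured compounds is known for this kind of exchange, so there is no measured guide to its size or direction.

The expectation for compound 3 is a step in this assay of about a 1.1-fold lower number from compound 1 to compound 3 (0.03 log units; within the scatter), a change small enough to sit within the usual scatter of repeated measurements, with no clear direction beyond it. On that basis compound 3 is expected to give roughly 5000 nM in this assay, within a range from 1500 nM to 17000 nM.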

Compound 3, half-maximal inhibitory concentration: "not active" (no number reported)
Nothing numeric was reported for compound 3, so the estimate cannot be set against anything.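

In this assay, for the compounds shown here, compound 3 is reported only as "not active", with no figure, so no step from compound 1 to compound 3 can be read. Nothing shown offers an explanation for this result. The compounds shown leave open how much exchanging 3-bromophenyl for 3,4-dichlorophenyl on the shared core changes the number in this assay.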